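A few compounds are considered here, and "the series" means these few. Any claim that something is new, unique, unknown or untested is made for them only; others in the source may bear on it.

All the compounds here share one core and differ in the group on a nitrogen on an aromatic ring. In an ADME assay on A549 cells (Homo sapiens) for cytotoxicity, read by resazurin assay, with a stated time of 48 h (a higher number here means that more compound is tolerated, a lower number that less compound is tolerated), compound 1 (`CC(=O)Nc1ccc(NC(=O)c2cc(Cl)ccc2O)c(Cl)c1`) has no usable result, reported as "not determined" (no result reported). Within the data shown here, compound 2 (`CCNc1ccc(NC(=O)c2cc(Cl)ccc2O)c(Cl)c1`) gives 30200 nM, and compound 3 (`CC(C)CNc1ccc(NC(=O)c2cc(Cl)ccc2O)c(Cl)c1`) gives 60000 nM, so compound 3 sits within the scatter of the only other number available.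

Compound 4 (`CCCCCCC(C)Nc1ccc(NC(=O)c2cc(Cl)ccc2O)c(Cl)c1`) has 1-methylheptyl in place of isobutyl on that nitrogen: 1-methylheptyl in place of isobutyl on a nitrogen on an aromatic ring. Among the measured compounds shown here, only one measured step bears on this change, a 2.0-fold higher number from compound 2 to compound 3 (0.30 log units; within the scatter). That step also alters the group on this nitrogen, but it is a smaller change and stays within the scatter, so it sets no direction. With this single step as a guide, no shift beyond the scatter is expected, although the larger change leaves real uncertainty. The expected result is a 1.5-fold lower number from compound 3 to compound 4 (0.18 log units; within the scatter). For compound 4, the estimated value is 40000 nM, with an expected range of 12000 nM to 100000 nM.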

Compound 4, half-maximal cytotoxic concentration: 23500 nM
The estimate for compound 4 lay 1.7-fold (0.23 log units) above the measured number, and the stated range covers the measured number.
By their numbers in this assay, from the lowest: compounds 4, 2 and 3 (each within the scatter of the next, the first and the last beyond it).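

In this assay, among these compounds, replacing isobutyl with the larger 1-methylheptyl on this nitrogen gives the first step at this position that lies beyond the scatter: a 2.6-fold lower number from compound 3 to compound 4 (0.41 log units; beyond the scatter), a modest drop in the concentration that cells tolerate. The same compound read against compound 2 gives a different picture, a 1.3-fold lower number from compound 2 to compound 4 (0.11 log units; within the scatter), which stays within the scatter, so these compounds show no steady trend with the size of the group on this nitrogen. Nothing available explains the step from isobutyl to 1-methylheptyl.

An unbranched octyl chain would show whether the length of the chain or its branching matters more here. A chain ending in an amine or a carboxylic acid, or a cyclohexyl group on this nitrogen, also remains an open case.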